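Swapping a chloro for a hydroxy on a phenyl ring

The source may hold more compounds than are shown below. What is called first, only, known or untested is meant among the compounds shown, and "the series" means these compounds.

Measured so far:
Compound 1, `O=C(CSc1nc(-c2ccccc2)c(C(=O)O)c(=O)[nH]1)Nn1c(COc2ccc(Cl)cc2Cl)nc2ccccc2c1=O`: 61.5%
Compound 2, `O=C(CSc1nc(-c2ccc(Cl)cc2)c(C(=O)O)c(=O)[nH]1)Nn1c(COc2ccc(Cl)cc2Cl)nc2ccccc2c1=O`: 51.9%

In a functional assay on the whole organism (strain albino) for inhibition, with Rattus norvegicus as the target, read by paw edema, with stated times of 1 h and 0.5 h, at a dose of 100 mg/kg by the oral route (a higher number here means more inhibition at the dose given (going by the name of the read-out), a lower number less inhibition), compound 2 gives 51.9%, the lower of two numbers, but its gap to compound 1 lies within the scatter, so the two cannot be ordered. Among the compounds with values here, compound 3, `O=C(CSc1nc(-c2ccc(O)cc2)c(C(=O)O)c(=O)[nH]1)Nn1c(COc2ccc(Cl)cc2Cl)nc2ccccc2c1=O`, is not yet measured. hydroxy in place of chloro on an aromatic carbon The only measured step, a number 9.6 percentage points lower from compound 1 to compound 2 (within the scatter), changed a different substituent and stayed within the scatter, so no step beyond the scatter is expected in this assay for this change either; the estimated step is a number 2.1 percentage points higher from compound 2 to compound 3 (within the scatter). Compound 3 is therefore expected to give about 54%, between 38% and 70%.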

Compound 3, a percentage reported as inhibition, in the whole organism at one dose (the size of the read-out at that dose, not a potency): 32.7%
For compound 3 the middle estimate is 21.3 percentage points above the measured one; the measured number lies below the stated range.
By their numbers in this assay, from the lowest: compound 3; then compounds 2 and 1 (each within the scatter of the next).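

Changing the group on this ring carbon can matter after all: in this assay hydroxy in place of chloro gives a number 19.2 percentage points lower from compound 2 to compound 3 (beyond the scatter) and hydroxy in place of hydrogen gives a number 28.8 percentage points lower from compound 1 to compound 3 (beyond the scatter) at the same place. Chloro and hydrogen could not be told apart here, whereas hydroxy stands apart from both. Nothing measured here explains this difference.

Going by these compounds, whether a methoxy group or an amine on the same carbon would follow hydroxy or fall in with chloro and hydrogen remains open.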